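Three limits and a fourth compound in the series

The source may hold more compounds than are shown below. What is called first, only, known or untested is meant among the compounds shown, and "the series" means these compounds.

Compound 1 `COc1cccc(Nc2nc3nonc3nc2Nc2cccc(OC)c2)c1`: > 100000 nM in an assay on mitochondria from L6 cells (Rattus norvegicus) for activation, with a stated time of 90 min (a lower number here means that less compound is needed, a higher number that more compound is needed for the effect), a limit of the assay.
Compound 2 `Cc1ccc(Nc2nc3nonc3nc2Nc2ccc(C)c(C)c2)cc1C`: > 100000 nM in this assay, a limit of the assay.
Compound 3 `Fc1ccccc1Nc1nc2nonc2nc1NCCC(F)(F)F`: > 100000 nM in this assay, a limit of the assay.

Compound 3 stands nowhere in particular on these numbers: its result is a limit, and so are the other two, all three sitting at the limit of > 100000 nM in this assay, at which 3 of the 3 values shown sit. No half-maximal effective concentration has yet been read as a number in this series.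

Compound 4 `Cc1ccc(Nc2nc3nonc3nc2Nc2ccccc2F)cc1` differs from compound 3 in one place: 4-methylphenyl in place of 3,3,3-trifluoropropyl on a nitrogen on an aromatic ring. With this change, compound 4 carries two aromatic amine groups on the shared core, as compound 1 and compound 2 do, and both of those gave only a limit.

For compound 4 the expected half-maximal effective concentration is 100000 nM, with a range from 30000 nM to 300000 nM. The expected step of a number no higher from compound 3 to compound 4 (the limit leaves the size open) is none beyond the scatter, since the starting point itself is a limit.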

Compound 4, half-maximal effective concentration: 2100 nM
Estimate against measurement, compound 4: 48-fold (1.68 log units) above, outside the stated range (below it).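

In this assay, the change of 3,3,3-trifluoropropyl to 4-methylphenyl on this nitrogen gives an at least 47-fold lower number from compound 3 to compound 4 (1.67 log units; beyond the scatter), so this position can decide whether the series yields a readable number at all. The size of the step stays open, as its starting point is a limit, and compound 4 is the only compound shown to give a number: the limit of > 100000 nM in this assay, at which 3 of the 4 values shown sit. Two aromatic amine groups on the shared core are not enough by themselves, since compound 1 and compound 2 carry them too and each gave only a limit.

The compounds shown leave open whether the methyl group of the 4-methylphenyl matters, or whether an unsubstituted phenyl, a 4-chlorophenyl or a pyridine ring at this nitrogen would serve as well. They also do not tell how a saturated ring such as cyclohexyl would compare there.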